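The source may report more compounds than this note shows. Statements on the series, on what has been measured and on what is new or still open speak of the compounds shown alone.

Working notes on the series.

The series is read in a functional assay on PC-3 cells (Homo sapiens) for inhibition, read by MTT assay, with a stated time of 24 h; a lower number here means a stronger inhibitor, a higher number a weaker inhibitor. Compound 1, `[O-]/[N+](=C\c1cn(-c2ccc(F)cc2)nn1)c1ccccc1`, gives 11400 nM there. Compound 2, `[O-]/[N+](=C\c1cn(-c2ccc(Cl)cc2)nn1)c1ccccc1`, gives 11100 nM in this assay; the step of a 1.0-fold lower number from compound 1 to compound 2 (0.01 log units; within the scatter) shows that swapping the halogen on the aryl group changes little. Compound 3, `[O-]/[N+](=C\c1cn(-c2ccc(F)cc2)nn1)Cc1ccccc1`, carries a benzyl group in place of the phenyl on the double-bonded nitrogen. In this assay compound 3 reaches only a limit of the measurement, > 100000 nM. The step of an at least 8.7-fold higher number from compound 1 to compound 3 (0.94 log units; beyond the scatter) is therefore known only as a lower bound, set by the limit of > 100000 nM in this assay, at which 1 of the 3 values shown sits.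

Compound 4, `[O-]/[N+](=C\c1cn(-c2ccc(C(F)(F)F)cc2)nn1)Cc1ccccc1`, is not yet measured. It differs from compound 3 by trifluoromethyl in place of fluoro on an aromatic carbon. For the measured compounds named here, no measured step covers exactly this exchange; the nearest comparison, the halogen swap between compound 1 and compound 2, lay within the scatter, while the benzyl group that compound 3 and compound 4 share is tied to the large loss seen from compound 1 to compound 3. The expectation is that compound 4 stays in the same weak range, so a step that the limit leaves unreadable from compound 3 to compound 4 is expected to be no real change. For compound 4 the estimate in this assay is 150000 nM, with a range from 50000 nM to 500000 nM, and a limit rather than a number is the likelier outcome.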

Compound 4, half-maximal inhibitory concentration: > 100000 nM
Compound 4: only a limit was reported; the forecaster's own chance of this, stated with the estimate: 70%; the middle value lies beyond the limit too.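

In this assay compound 4 gives > 100000 nM, which is a limit and not a number. For the compounds shown here, compound 3 stands at the same limit, so no step from compound 3 to compound 4 can be read: the limit of > 100000 nM in this assay, at which 2 of the 4 values shown sit. The compounds shown leave open whether trifluoromethyl in place of fluoro makes any difference in compounds carrying the benzyl group.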